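The compounds below may be only part of what the source reports. "The series", "measured", "known", "first", "only" and "open" are said of these compounds alone.

Compound 1 `C=CCNC(=O)n1c(-c2ccc(OC)cc2)cc(=O)c2c(OC)cc(OC)cc21`: 12000 nM
Compound 2 `COc1ccc(-c2cc(=O)c3c(OC)cc(OC)cc3n2S(=O)(=O)c2cc(F)c(F)c(F)c2)cc1`: > 65500 nM
Compound 3 `COc1ccc(-c2cc(=O)c3c(OC)cc(OC)cc3n2S(=O)(=O)c2cc(Cl)cc(Cl)c2O)cc1`: > 37900 nM

For the measured compounds named here, in a functional assay on KOPN-8 cells (Homo sapiens) for antiproliferative activity, with a stated time of 72 h (a lower number here means that less compound is needed, a higher number that more compound is needed for the effect), compound 1 gives 12000 nM, the only number among the three values shown. Compound 2 reaches only a limit, > 65500 nM, the evidence being (the limit of > 65500 nM in this assay, at which 1 of the 3 values shown sits). Compound 3 likewise reaches only a limit, > 37900 nM, the evidence being (the limit of > 37900 nM in this assay, at which 1 of the 3 values shown sits). Going by the values given here, the one step between measured compounds, a step that the two limits leave unreadable from compound 2 to compound 3, cannot be read from those two limits, so its size is unknown.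

Compound 4 `COc1ccc(-c2cc(=O)c3c(OC)cc(OC)cc3n2S(=O)(=O)c2ccc(OC)cc2)cc1` differs from compound 1 in that ((4-methoxyphenyl)sulfonyl in place of allylcarbamoyl on an aromatic nitrogen). Among the compounds with values here, no measured step covers this particular change. Compound 2 and compound 3 carry a sulfonyl group on the same aromatic nitrogen, and both sit at limits. A step of a 3.3-fold higher number from compound 1 to compound 4 (0.52 log units; beyond the scatter) toward a higher value in this assay is therefore expected for this change, with a real chance that only a limit is reached. The estimate for compound 4 in this assay is 40000 nM, with a range from 10000 nM to 120000 nM.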

Compound 4, half-maximal effective concentration: > 82700 nM
Compound 4: a limit, no number; the forecaster's own chance of this, stated with the estimate: 55%; middle value at least 2.0-fold (0.31 log units) away from the limit.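

For the compounds shown here, putting (4-methoxyphenyl)sulfonyl in place of allylcarbamoyl on the aromatic nitrogen gives an at least 6.8-fold higher number from compound 1 to compound 4 (0.83 log units; beyond the scatter) in this assay, the only readable step at this position. Compound 4 reaches only a limit, so the true size of that step stays open: the limit of > 82700 nM in this assay, at which 1 of the 4 values shown sits. With compound 4, a sulfonyl group carrying a 4-methoxyphenyl ring also gives no number, as do the 3,4,5-trifluorophenyl and 3,5-dichloro-2-hydroxyphenyl rings of compound 2 and compound 3, and the steps among these three limits cannot be read.

The compounds shown leave open whether any aryl group on the sulfonyl sulfur would give a number in this assay. They also leave open whether a carbamoyl group carrying a longer chain or a terminal amine would give a lower number than compound 1.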